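Pyrimidin-2-yl for (1H-imidazol-2-yl)methyl on the ring amine nitrogen

The compounds below may be only part of what the source reports. "The series", "measured", "known", "first", "only" and "open" are said of these compounds alone.

Measured so far:
compound 1 `c1c[nH]c(CN2CCN(CCCc3c[nH]c4ccc(-n5cnnc5)cc34)CC2)n1` gives 1.6 nM in an assay on CHO cells for displacement of a labelled ligand from 5-hydroxytryptamine receptor 1D (Homo sapiens); a lower number here means a stronger inhibitor, a higher number a weaker inhibitor
compound 2 `CC(=O)Nc1ccc(CN2CCN(CCCc3c[nH]c4ccc(-n5cnnc5)cc34)CC2)cc1` gives 2.5 nM
compound 3 `CN(C)C(=O)C(c1ccccc1)N1CCN(CCCc2c[nH]c3ccc(-n4cnnc4)cc23)CC1` gives 1 nM

Compound 1 stands second highest of the three numbers in this assay. Its nearest neighbour is compound 2, a 1.6-fold higher number from compound 1 to compound 2 (0.19 log units; within the scatter). Compound 3 sits at the other end, and its value against that of compound 1 is likewise within the scatter, so the three measured compounds show no separation that can be read as order.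

The new member, compound 4 `c1cnc(N2CCN(CCCc3c[nH]c4ccc(-n5cnnc5)cc34)CC2)nc1`, differs from compound 1 in one place: pyrimidin-2-yl in place of (1H-imidazol-2-yl)methyl on an amine nitrogen in a ring. Among the measured compounds shown here, the only step that bears on it is the one from compound 1 to compound 2, which exchanges the group carried at the same ring amine nitrogen through a saturated chain carbon; it is within the scatter. Compound 3 also varies this position, again without moving beyond the scatter. For the measured compounds named here, the change to compound 4 goes further, since the saturated chain carbon leaves along with the ring and the new ring joins the amine nitrogen directly; no measured step covers that. On the evidence of the series, no step beyond the scatter is expected in this assay, in either direction, with the range widened for the untested direct attachment.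

Compound 4 is therefore estimated at 2.5 nM, between 0.8 nM and 8 nM, which would be an expected step of a 1.6-fold higher number from compound 1 to compound 4 (0.19 log units; within the scatter).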

Compound 4, half-maximal inhibitory concentration: 0.6 nM
The estimate for compound 4 lay 4.2-fold (0.62 log units) above the measured number; measured number below the stated range.
By their numbers in this assay, from the lowest: compounds 4, 3, 1 and 2 (each within the scatter of the next, the first and the last beyond it).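

In this assay, the substituent on the ring amine nitrogen now gives its first steps beyond the scatter, though both are modest: a 2.7-fold lower number from compound 1 to compound 4 (0.43 log units; beyond the scatter), and a 4.2-fold lower number from compound 2 to compound 4 (0.62 log units; beyond the scatter). Direct attachment of an aromatic ring to the amine nitrogen, with no saturated chain carbon, is therefore tolerated here and lowers the number relative to these two benzylic-type substituents, while compound 4 stays within the scatter of compound 3, so no order can be read for that pair. Nothing measured on these compounds accounts for the step.

The change to compound 4 alters several things at once: the saturated chain carbon goes, the five-membered ring becomes a six-membered one, and the hydrogen-bond donor of the 1H-imidazol-2-yl group leaves, so the step cannot yet be assigned to any one of them. A (pyrimidin-2-yl)methyl group would separate the chain carbon from the ring, and a pyridin-2-yl or plain phenyl group on the same nitrogen would show whether the ring nitrogens of pyrimidin-2-yl matter to the lower number.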